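Ortho-bromo for meta-fluoro on the isoxazole phenyl

A few compounds are considered here, and "the series" means these few. Any claim that something is new, unique, unknown or untested is made for them only; others in the source may bear on it.

Measured in an ADME assay on cells (Fibroblast, Homo sapiens) for cytotoxicity, with a stated time of 48 h; a lower number here means a stronger inhibitor, a higher number a weaker inhibitor:
- compound 1 `O=[N+]([O-])c1ccc(CN2CCC(n3cc(CC(OCc4cc(-c5ccccc5)no4)c4ccc(Br)cc4)nn3)CC2)cc1` gives > 25000 nM, a limit of the assay and not a number.
- compound 2 `O=[N+]([O-])c1ccc(CN2CCC(n3cc(CC(OCc4cc(-c5cccc(Br)c5)no4)c4ccc(Br)cc4)nn3)CC2)cc1` gives > 25000 nM, also a limit.
- compound 3 `O=[N+]([O-])c1ccc(CN2CCC(n3cc(CC(OCc4cc(-c5cccc(F)c5)no4)c4ccc(Br)cc4)nn3)CC2)cc1` gives 10000 nM.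

Among the measured compounds shown here, compound 3 holds the only number among the three; the other two values sit at the limit of > 25000 nM in this assay, at which 2 of the 3 values shown sit. The move from the unsubstituted phenyl to the 3-fluorophenyl reads as an at least 2.5-fold lower number from compound 1 to compound 3 (0.39 log units; beyond the scatter), and the move from the 3-bromophenyl to the 3-fluorophenyl reads as an at least 2.5-fold lower number from compound 2 to compound 3 (0.39 log units; beyond the scatter). Between the first two the step is a step that the two limits leave unreadable from compound 1 to compound 2.

Compound 4 `O=[N+]([O-])c1ccc(CN2CCC(n3cc(CC(OCc4cc(-c5ccccc5Br)no4)c4ccc(Br)cc4)nn3)CC2)cc1` differs from compound 3 by 2-bromophenyl in place of 3-fluorophenyl on an aromatic carbon. The nearest measured guide is the fluoro-to-bromo exchange seen in reverse as an at least 2.5-fold lower number from compound 2 to compound 3 (0.39 log units; beyond the scatter), which points to a higher number when bromine replaces fluorine on that phenyl, though the bromine in compound 4 sits at a different place on the ring than in compound 2, so the match is only partial. Compound 4 is therefore expected to show a 2.2-fold higher number from compound 3 to compound 4 (0.34 log units; beyond the scatter), returning toward the limit. For compound 4 the estimate in this assay is 22000 nM, with a range from 8000 nM to 60000 nM, and a fair chance that only a limit is reported.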

Compound 4, half-maximal inhibitory concentration: > 25000 nM
Compound 4 was reported as a limit; the forecaster's own chance of this, stated with the estimate: 55%; middle value at least 1.1-fold (0.05 log units) from the limit.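

In this assay compound 4, with its 2-bromophenyl, gives > 25000 nM, which is a limit of the assay and not a number. Among the compounds shown here, exchanging the 3-fluorophenyl of compound 3 for this group reads as an at least 2.5-fold higher number from compound 3 to compound 4 (0.39 log units; beyond the scatter), so bromine at a second place on the phenyl, in compound 4 as in compound 2, does not bring back the lower number of the 3-fluorophenyl, and compound 3 remains the only compound with a number: the limit of > 25000 nM in this assay, at which 3 of the 4 values shown sit. The steps to compound 4 from compound 1 and from compound 2 cannot be read, since both ends of each are limits, so the 2-bromophenyl and 3-bromophenyl cannot be ranked against each other or against the unsubstituted phenyl.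

The compounds shown leave open whether the lower number of compound 3 follows fluorine itself or its place on the ring, which a 2-fluorophenyl or a 4-fluorophenyl would separate. They also leave open where a 3-chlorophenyl or a 3-methoxyphenyl would fall relative to the 3-fluorophenyl and the limit.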